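Hydroxamic acid amide series: aryl substituent variation on the nitrogen

The source may hold more compounds than are shown below. What is called first, only, known or untested is meant among the compounds shown, and "the series" means these compounds.

Measured compounds:
compound 1 `O=C(NO)C(F)(F)C(F)(F)C(F)(F)C(F)(F)C(F)(F)C(F)(F)C(=O)Nc1ccc(I)cc1`, 36000 nM
compound 2 `O=C(NO)C(F)(F)C(F)(F)C(F)(F)C(F)(F)C(F)(F)C(F)(F)C(=O)Nc1nc(-c2ccccc2)cs1`, 1500 nM

For the measured compounds named here, in an assay on isolated protein for inhibition of histone deacetylase 8 (Homo sapiens), read by fluorescence (a lower number here means tighter binding, a higher number weaker binding), compound 2 gives 1500 nM, the lowest of the two numbers so far, and the only step in this assay, a 24-fold lower number from compound 1 to compound 2 (1.38 log units; beyond the scatter), separates it from compound 1 with 36000 nM.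

Compound 3 `O=C(NO)C(F)(F)C(F)(F)C(F)(F)C(F)(F)C(F)(F)C(F)(F)C(=O)Nc1cccc(-c2ccccc2)c1` is the next member to measure. It differs from compound 2 by 3-phenylphenyl in place of 4-phenyl-1,3-thiazol-2-yl on an amide-type nitrogen, so the five-membered ring with two hetero atoms is replaced by a second six-membered ring of carbon only, with no hydrogen-bond acceptors remaining in the group.

Going by the values given here, no measured step covers this exact exchange. Among the compounds with values here, the one step available, a 24-fold lower number from compound 1 to compound 2 (1.38 log units; beyond the scatter), shows that the group on the amide nitrogen can move this assay a great deal, and that the group with two hetero atoms gave the lower number. Compound 3, carrying only carbon rings like compound 1, is therefore expected to fall between the two measured values, with a step of a 3.3-fold higher number from compound 2 to compound 3 (0.52 log units; beyond the scatter). The estimate for compound 3 is 5000 nM, within 1500 nM to 20000 nM.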

Compound 3, dissociation constant: 60000 nM
The estimate for compound 3 lay 12-fold (1.08 log units) below the measured number; measured number above the stated range.
By their numbers in this assay, from the lowest: compound 2; then compounds 1 and 3 (each within the scatter of the next).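

In this assay, the exchange gives a 40-fold higher number from compound 2 to compound 3 (1.60 log units; beyond the scatter), so the lower number of compound 2 does not carry over to the all-carbon 3-phenylphenyl group, even though that group also ends in a phenyl ring. Against 4-iodophenyl, the same group gives a 1.7-fold higher number from compound 1 to compound 3 (0.22 log units; within the scatter), which lies within the scatter, so among these three compounds only the 4-phenyl-1,3-thiazol-2-yl group stands apart at this amide-type nitrogen. No supporting data bear on what underlies this difference.

On these data alone, it remains open whether the ring nitrogen or the sulfur accounts for the gap, a question that an oxazole or pyridine ring carrying a phenyl group at the same nitrogen would help to separate. Also open, as far as these compounds go, is whether the same ranking holds with a plain hydrocarbon chain in place of the fluorinated chain.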